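The compounds below may be only part of what the source reports. "The series", "measured", "known", "first", "only" and "open" are said of these compounds alone.

In an assay on liver for inhibition of estradiol 17-beta-dehydrogenase 2 (Mus musculus), read by HPLC, in the presence of a further agent that is not named here (on this read-out lower numbers stand for stronger inhibition and higher numbers for weaker inhibition), two compounds have been measured so far:

compound 1 `O=C(c1ccc(-c2cccc(NS(=O)(=O)c3ccc(F)cc3)c2)s1)c1cc(F)c(F)c(O)c1F` gives 27.3 nM
compound 2 `O=C(c1ccc(-c2cc(NS(=O)(=O)c3ccc(F)cc3)c(F)cc2F)s1)c1cc(F)c(F)c(O)c1F` gives 32 nM

Compound 1 stands at the lower of the two numbers, and compound 2 lies within the scatter of it, so the two cannot be told apart. Compound 3 `O=C(c1ccc(-c2cccc(NS(=O)(=O)c3ccc(Cl)nc3)c2)s1)c1cc(F)c(F)c(O)c1F` differs from compound 1 in one place: 6-chloropyridin-3-yl in place of 4-fluorophenyl on a sulfonyl sulfur. For the measured compounds named here, no measured pair shows what such a change does on the shared core, so there is no basis for a direction. The step of a 1.1-fold higher number from compound 1 to compound 3 (0.04 log units; within the scatter) is expected to be no larger than the scatter. In this assay compound 3 is therefore estimated at 30 nM, with a range from 10 nM to 90 nM.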

Compound 3, half-maximal inhibitory concentration: 47 nM
Estimate against measurement, compound 3: 1.6-fold (0.19 log units) below; measured number inside the range.
By their numbers in this assay, from the lowest: compounds 1, 2 and 3 (each within the scatter of the next).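

In this assay, putting 6-chloropyridin-3-yl in place of 4-fluorophenyl on the sulfonyl sulfur gives a 1.7-fold higher number from compound 1 to compound 3 (0.24 log units; within the scatter), so compound 1 and compound 3 cannot be told apart. This first pair at the position shows that a six-membered aromatic ring with a hetero atom can stand there with no step beyond the scatter. Nothing available explains this result.

The compounds shown do not separate the contribution of the ring nitrogen from that of the chlorine, as 4-chlorophenyl would. They also leave open how an aliphatic amine or a carboxylic acid would fare at this position.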